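This account rests on a few compounds, and the source may have more. Where it says the series, first, only, none or still open, it means among the compounds named here.

Compound 3 is `CC[C@H](C)[C@H](N)CN(C(=O)[C@@H]1C[C@H]1c1ccccc1Cl)c1ccc(-c2ccccc2)cc1`. In a functional assay for agonist activity at G protein-coupled receptor 88 (Homo sapiens), read by HTRF and cAMP accumulation (on this read-out lower numbers stand for an effect already at smaller amounts and higher numbers for an effect only at larger amounts of compound), compound 3 gives only a limit, > 25000 nM, and no single number. That limit is the limit of > 25000 nM in this assay, at which 1 of the 3 values shown sits. The related compound 1, `CC[C@H](C)[C@H](N)CN(C(=O)[C@@H]1C[C@H]1c1ccccc1)c1ccc(-c2ccccc2)cc1`, which carries the plain phenyl on the same saturated ring carbon, is recorded in this assay with the several entries of compound 1 in this assay, 230 nM; 800 nM (2 entries), so compound 1 gives 230 nM; 800 nM (2 entries). Compound 2, `CCC(CC)C(N)CCN(C(=O)[C@@H]1C[C@H]1c1ccccc1)c1ccc(-c2ccccc2)cc1`, gives 2 nM in this assay. Within the data shown here, no step between measured compounds has been worked out for this set, so the pair of compound 1 and compound 3 shows only that one gives numbers and the other a limit.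

Compound 4 is `CC[C@H](C)[C@H](N)CN(C(=O)[C@@H]1C[C@H]1c1ccc(F)cc1)c1ccc(-c2ccccc2)cc1`. It differs from compound 3 by 4-fluorophenyl in place of 2-chlorophenyl on a saturated ring carbon. Given that compound 1 with the plain phenyl gives 230 nM; 800 nM (2 entries), compound 4 is expected to move well beyond the scatter toward smaller concentrations, a step of an at least 41-fold lower number from compound 3 to compound 4 (1.61 log units; beyond the scatter). Compound 4 is therefore estimated at 600 nM, with a range from 100 nM to 10000 nM.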

Compound 4, half-maximal effective concentration: 600 nM
Compound 4: the middle estimate sits on the measured number at the digits printed, within the range that was stated.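

In this assay, the step of an at least 41-fold lower number from compound 3 to compound 4 (1.61 log units; beyond the scatter) shows that a substituted phenyl on this saturated ring carbon does not by itself end the effect. Among these compounds, compound 4 gives 600 nM and compound 1 gives 230 nM; 800 nM (2 entries), and the single value of compound 4 lies inside the span of the entries of compound 1, so 4-fluorophenyl can stand where the plain phenyl stands. The reading for compound 3 remains a limit and not a number: the limit of > 25000 nM in this assay, at which 1 of the 4 values shown sits.

The step exchanges the halogen and its place on the phenyl together, and the compounds shown do not separate these two changes. Also open, going by these compounds, is how this carbon would tolerate a phenyl carrying a methoxy group, a nitrile or an amine.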